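The source may report more compounds than this note shows. Statements on the series, on what has been measured and on what is new or still open speak of the compounds shown alone.

Measured in a functional assay on HepG2 cells (Homo sapiens) for antiproliferative activity, read by CCK-8 assay, with a stated time of 48 h; on this read-out higher numbers stand for weaker inhibition and lower numbers for stronger inhibition:
- compound 1 `O=C(Nc1ccccc1)c1cc(Oc2ccc(/C=C/c3ccccn3)cc2)ccn1` gives 30200 nM
- compound 2 `O=C(NC1CC1)c1cc(Oc2ccc(/C=C/c3ccccn3)cc2)ccn1` gives 31000 nM
- compound 3 `O=C(Nc1ccccc1)c1cc(Oc2ccc(/C=C/c3ccncc3)cc2)ccn1` gives no number, only the limit > 100000 nM

Compound 3 therefore stands beyond the highest number the assay reports, at the limit of > 100000 nM in this assay, at which 1 of the 3 values shown sits, and the step of an at least 3.3-fold higher number from compound 1 to compound 3 (0.51 log units; beyond the scatter) shows that swapping the pyridine ring on the double-bonded chain carbon pushed the number out of the measurable range. Compound 4 `O=C(c1cc(Oc2ccc(/C=C/c3ccncc3)cc2)ccn1)N1CCCC1` keeps this weaker pyridin-4-yl arrangement of compound 3 and differs from it only at the amide end: pyrrolidin-1-yl in place of anilino on a carbonyl carbon. The measured step that bears on such an amide change is a 1.0-fold higher number from compound 1 to compound 2 (0.01 log units; within the scatter), and there an exchange of the group on the amide-type nitrogen left the number unchanged within the scatter. Accordingly the expected step that the limit leaves unreadable from compound 3 to compound 4 is none beyond the scatter, and because compound 3 already sits at the limit of > 100000 nM in this assay, at which 1 of the 3 values shown sits, the most likely outcome for compound 4 is again a limit. Compound 4 is estimated at about 150000 nM, with a range from 50000 nM to 500000 nM.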

Compound 4, half-maximal inhibitory concentration: 41600 nM
The estimate for compound 4 lay 3.6-fold (0.56 log units) above the measured number, outside the stated range (below it).
By their numbers in this assay, from the lowest: compounds 1, 2 and 4 (each within the scatter of the next). At a limit, above all of these: compound 3.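

Compound 3 is held only as a limit in this assay, not as a number: the limit of > 100000 nM in this assay, at which 1 of the 4 values shown sits.

With pyrrolidin-1-yl in place of anilino on the carbonyl carbon, the result is a measured value, with an at least 2.4-fold lower number from compound 3 to compound 4 (0.38 log units; beyond the scatter), so the pyridin-4-yl arrangement does not by itself keep a compound at the limit. The group on the carbonyl carbon therefore counts in this pair, unlike the pyridin-2-yl pair with cyclopropyl in place of phenyl, which shows a 1.0-fold higher number from compound 1 to compound 2 (0.01 log units; within the scatter).

As far as these compounds go, the true size of the new step stays open, since one end of it is a limit, as does whether pyrrolidin-1-yl would have any effect alongside pyridin-2-yl. Also open, from the compounds shown here alone, is how a piperidine ring, a morpholine ring or an open-chain dimethylamino group would behave on the same carbonyl carbon.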